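This account rests on a few compounds, and the source may have more. Where it says the series, first, only, none or still open, it means among the compounds named here.

Measured so far:
compound 1, `COc1ccc2ncc(S(=O)(=O)c3ccc(C)c(F)c3)c(N3CCC(C)CC3)c2c1`, in an assay on isolated protein for displacement of a labelled ligand from metabotropic glutamate receptor 5 (Homo sapiens), with a stated time of 60 min, tested at 1 uM; on this read-out lower numbers stand for less inhibition and higher numbers for more inhibition at the one concentration tested (going by the name of the read-out): 73%
compound 2, `COc1ccc2ncc(S(=O)(=O)c3cc(F)cc(F)c3)c(N3CCC(C)CC3)c2c1`, in this assay: 30%

Compound 1 stands highest of the two numbers in this assay; its nearest neighbour is compound 2, and the step of a number 43 percentage points lower from compound 1 to compound 2 (beyond the scatter) lies beyond the scatter. That step, 3,5-difluorophenyl in place of 3-fluoro-4-methylphenyl on a sulfonyl sulfur, concerns the group on the sulfonyl sulfur and not the shared core.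

Compound 3, `Cc1ccc2ncc(S(=O)(=O)c3ccc(C)c(F)c3)c(N3CCC(C)CC3)c2c1`, differs from compound 1 elsewhere: methyl in place of methoxy on an aromatic carbon. Within the data shown here, no measured step touches the core of compound 1, so the two measured compounds give no precedent for methyl in place of methoxy on an aromatic carbon. Compound 3 is therefore expected to lie close to compound 1, with a step of a number 8 percentage points lower from compound 1 to compound 3 (within the scatter) expected to stay within the scatter, though the lack of precedent leaves the range wide. The estimate for compound 3 in this assay is 65%, between 40% and 85%.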

Compound 3, a percentage reported as inhibition, at one concentration (the size of the read-out at that concentration, not a potency): 91%
The estimate for compound 3 lay 26 percentage points below the measured number, and the stated range ends below it.
By their numbers in this assay, from the lowest: compound 2; then compound 1; then compound 3.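

In this assay, the shared core proves not to be a silent part of these compounds: a number 18 percentage points higher from compound 1 to compound 3 (beyond the scatter), so this aromatic carbon also moves the number, as the group on the sulfonyl sulfur already did. Methoxy leaves with its oxygen and its one hydrogen-bond acceptor, and methyl, with one heavy atom and no acceptor, gives the higher number, though this rests on a single pair. Nothing on hand accounts for the rise.

The compounds shown leave open how a chlorine atom, an amine or a longer chain such as ethoxy would compare on this aromatic carbon. They also leave open whether the gain from methyl carries over to compounds with 3,5-difluorophenyl on the sulfonyl sulfur.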